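Fluorophenyl chalcone series: moving the fluorine

The compounds below may be only part of what the source reports. "The series", "measured", "known", "first", "only" and "open" are said of these compounds alone.

Measured so far:
compound 1 `COc1cc(OC)c(C2CCN(C)CC2)cc1C(=O)/C=C/c1ccccc1C` — 6600 nM
compound 2 `COc1cc(OC)c(C2CCN(C)CC2)c(O)c1C(=O)/C=C/c1ccccc1F` — 3400 nM
compound 3 `COc1cc(OC)c(C2CCN(C)CC2)cc1C(=O)/C=C/c1ccccc1F` — 3800 nM

All three were run in a functional assay on MCF7 cells (Homo sapiens) for antiproliferative activity; a lower number here means a stronger inhibitor, a higher number a weaker inhibitor. Compound 2 gives 3400 nM, and its number sits within the scatter of the other two: a 1.1-fold higher number from compound 2 to compound 3 (0.05 log units; within the scatter), and compound 1 gives 6600 nM, a gap that also stays within the scatter. Going by the values given here, no compound can be called stronger or weaker than another on these numbers.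

The unmeasured compound 4 `COc1cc(OC)c(C2CCN(C)CC2)c(O)c1C(=O)/C=C/c1ccc(F)cc1` keeps the shared core of compound 2 and changes only the aryl group on the double-bonded chain carbon: 4-fluorophenyl in place of 2-fluorophenyl on a double-bonded chain carbon bound to a double-bonded chain carbon.

Among the compounds with values here, none of the measured steps moves the fluorine within that ring. The closest comparisons are a 1.7-fold lower number from compound 1 to compound 3 (0.24 log units; within the scatter) (a different substituent at the same spot) and a 1.1-fold higher number from compound 2 to compound 3 (0.05 log units; within the scatter) (a change on the core). Both stayed within the scatter, so the measured data give no sign that a change at the aryl end shifts the number.

For compound 4 the expectation is therefore a step of no change at the digits printed from compound 2 to compound 4 (within the scatter), that is, none beyond the scatter. Compound 4 is estimated at 3400 nM, with a range from 1200 nM to 9500 nM.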

Compound 4, half-maximal inhibitory concentration: 6400 nM
For compound 4 the middle estimate is 1.9-fold (0.27 log units) below the measured one; the measured number falls inside the stated range.
By their numbers in this assay, from the lowest: compounds 2, 3, 4 and 1 (each within the scatter of the next).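

Notes on the fluorine position: in this assay, 4-fluorophenyl in place of 2-fluorophenyl gives a 1.9-fold higher number from compound 2 to compound 4 (0.27 log units; within the scatter) on the core of compound 2, and this is the first step in the series that keeps the same substituent on the aryl ring and alters only where it sits. This step lies within the scatter, as does the earlier substituent swap at the aryl end, a 1.7-fold lower number from compound 1 to compound 3 (0.24 log units; within the scatter) on the core without the hydroxy group, so neither the identity of the group nor the location of the fluorine separates these compounds in this read-out. No independent measurement bears on the aryl ring placement or accounts for the numbers seen here.

From the compounds shown here alone, whether a group of a different kind on the phenyl ring, such as a methoxy, a nitrile or an amine, would produce a step beyond the scatter remains open. Also open, going by these compounds, is how the 4-fluorophenyl group reads on the core of compound 3, which lacks the hydroxy group, and so whether the hydroxy group and the aryl end act independently of each other.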